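Thiophen-2-yl for furan-3-yl: expected effect on binding

This account rests on a few compounds, and the source may have more. Where it says the series, first, only, none or still open, it means among the compounds named here.

compound 1 `CC1=C(C(=O)OCC(C)C)C(c2cccs2)NC(=O)N1` — 25%
compound 2 `CC1=C(C(=O)SC(C)C)C(c2ccoc2)NC(=O)N1` — 9%

In an assay on membranes from CHO cells for displacement of a labelled ligand from adenosine receptor A1 (Homo sapiens), read by scintillation counting, with a stated time of 60 min, tested at 1 uM (a lower number here means less inhibition, a higher number more inhibition at the concentration tested (going by the name of the read-out)), compound 1 gives 25% and compound 2 gives 9%. Compound 2 thus stands lowest of the two numbers, and its gap to compound 1 lies beyond the usual scatter. Compound 1 and compound 2 differ in two places at once, so their two values only show that the pair lies apart; which change carries the gap cannot be read from them.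

Compound 3 `CC1=C(C(=O)SC(C)C)C(c2cccs2)NC(=O)N1` is not yet measured. It differs from compound 2 in one place: thiophen-2-yl in place of furan-3-yl on a saturated ring carbon. Compound 3 thus carries the same five-membered ring as compound 1 and the same (isopropylsulfanyl)carbonyl group as compound 2. Within the data shown here, no measured step of this single kind exists in the set, so the direction rests on the pair of values alone. The step that is expected is a number 9 percentage points higher from compound 2 to compound 3 (within the scatter). Compound 3 is expected to give 18%, with a range from 4% to 36%.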

Compound 3, a percentage reported as inhibition, at one concentration (the size of the read-out at that concentration, not a potency): 1%
Estimate against measurement, compound 3: 17 percentage points above; measured number below the stated range.
By their numbers in this assay, from the lowest: compounds 3 and 2 (each within the scatter of the next); then compound 1.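

In this assay the exchange of furan-3-yl for thiophen-2-yl on the saturated ring carbon, with the (isopropylsulfanyl)carbonyl group held fixed, gives a number 8 percentage points lower from compound 2 to compound 3 (within the scatter) and thus leaves the two five-membered rings indistinguishable at this position. Among these compounds, with thiophen-2-yl held fixed, isopropylsulfanyl in place of isobutoxy on a carbonyl carbon gives a number 24 percentage points lower from compound 1 to compound 3 (beyond the scatter) and is the only single change that lies beyond the scatter, so the earlier gap between two compounds differing in two places now has a modest single-change counterpart at the carbonyl group, not at the ring. No measurement available here bears on the reason for either step.

The carbonyl change alters the linking atom and the chain together, so isopropoxy on the same carbonyl carbon would be needed to separate the sulfur from the shorter branched chain. Furan-2-yl or thiophen-3-yl on the saturated ring carbon would likewise separate the ring hetero atom from the point of attachment, and the ring exchange remains open with isobutoxy on the carbonyl carbon.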